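Replacing cyclopropyloxy with acetyl on a shared imidazoline scaffold

This account rests on a few compounds, and the source may have more. Where it says the series, first, only, none or still open, it means among the compounds named here.

Of the compounds shown here, three sharing one core have been tested in an assay on CHO cells for displacement of a labelled ligand from Alpha-2C adrenergic receptor (Homo sapiens); a higher number here means a weaker inhibitor, a lower number a stronger inhibitor. Compound 1 `C=C(C)c1ccccc1OC(C)C1=NCCN1` gives 603 nM, compound 2 `CC(C)Oc1ccccc1OC(C)C1=NCCN1` gives 398 nM, and compound 3 `CC(Oc1ccccc1OC1CC1)C1=NCCN1` gives 676 nM. Compound 3 carries the highest of the three numbers, yet the steps to it are small: a 1.1-fold higher number from compound 1 to compound 3 (0.05 log units; within the scatter) and a 1.7-fold higher number from compound 2 to compound 3 (0.23 log units; within the scatter), both within the scatter, as is a 1.5-fold lower number from compound 1 to compound 2 (0.18 log units; within the scatter). The next compound, compound 4 `CC(=O)c1ccccc1OC(C)C1=NCCN1`, differs from compound 3 in one place: acetyl in place of cyclopropyloxy on an aromatic carbon. Within the data shown here, no measured step introduces acetyl, so none bears on this change directly; what the three measured steps show is that exchanging groups at this aromatic carbon among 1-methylethenyl, isopropoxy and cyclopropyloxy never moved the number beyond the scatter. On that basis no step beyond the scatter is expected in this assay from compound 3 to compound 4, and the estimated step is a 1.1-fold lower number from compound 3 to compound 4 (0.05 log units; within the scatter). Compound 4 is therefore expected to give about 600 nM, with a range from 250 nM to 1500 nM.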

Compound 4, inhibition constant: 7410 nM
For compound 4 the middle estimate is 12-fold (1.09 log units) below the measured one; the whole stated range lies below it.
By their numbers in this assay, from the lowest: compounds 2, 1 and 3 (each within the scatter of the next); then compound 4.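

In this assay, the aromatic carbon that carried 1-methylethenyl, isopropoxy and cyclopropyloxy with no change beyond the scatter does not accept every group, for acetyl there gives an 11-fold higher number from compound 3 to compound 4 (1.04 log units; beyond the scatter) and a 19-fold higher number from compound 2 to compound 4 (1.27 log units; beyond the scatter) and also a 12-fold higher number from compound 1 to compound 4 (1.09 log units; beyond the scatter) as the steps to the other three compounds. The counts of hydrogen-bond donors and acceptors and the net charge are the same for cyclopropyloxy and acetyl, so these counts do not separate the two groups. A double bond outside aromatic rings is not enough on its own either: compound 1 carries one in its 1-methylethenyl group yet stays within the scatter of compounds 2 and 3.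

Nothing among the data shown accounts for the rise in the number at compound 4. On these data alone, it remains open whether the result is particular to acetyl or extends to other carbonyl groups on this aromatic carbon, such as a methyl ester or a primary amide, and how an amine there would behave.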